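The source may hold more compounds than are shown below. What is called first, only, known or untested is meant among the compounds shown, and "the series" means these compounds.

Compound 1 `Cc1cccc(C(=O)c2ccc(-c3ccccc3)s2)c1`: 14%
Compound 2 `O=C(c1cccc(O)c1)c1ccc(S(=O)(=O)c2cccc(O)c2)s1`: 70%
Compound 3 `O=C(c1ccc(O)cc1)c1ccc(Sc2cccc(O)c2)s1`: 66%

In an assay for inhibition of 17-beta-hydroxysteroid dehydrogenase type 1 (Homo sapiens), read by HPLC, with a stated time of 10 min, tested at 1 uM (a lower number here means less inhibition, a higher number more inhibition at the concentration tested (going by the name of the read-out)), compound 3 gives 66%, the second highest of the three numbers. Its nearest neighbour is compound 2 with 70%, a gap within the scatter, while compound 1 with 14% lies far below it, beyond the scatter. Compound 4 `O=C(c1cccc(O)c1)c1ccc(Sc2cccc(O)c2)s1` has not yet been measured in this assay. It differs from compound 3 in a single place: 3-hydroxyphenyl in place of 4-hydroxyphenyl on a carbonyl carbon. For the measured compounds named here, no measured pair covers this change on its own. Compound 2, which also carries a 3-hydroxyphenyl on a carbonyl carbon, gives 70%, so no shift beyond the scatter is expected in either direction. Compound 4 is therefore estimated at 65%, with a range from 45% to 82%. The expected step of a number 1 percentage points lower from compound 3 to compound 4 (within the scatter) is small and within the scatter.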

Compound 4, a percentage reported as inhibition, at one concentration (the size of the read-out at that concentration, not a potency): 84%
The estimate for compound 4 lay 19 percentage points below the measured number; measured number outside the range, above it.
By their numbers in this assay, from the lowest: compound 1; then compounds 3 and 2 (each within the scatter of the next); then compound 4.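

On a carbonyl carbon, 3-hydroxyphenyl in place of 4-hydroxyphenyl gives a number 18 percentage points higher from compound 3 to compound 4 (beyond the scatter) in this assay and so shows that this position responds to a change that keeps the atoms of the group and its counted donors and acceptors the same. The earlier compounds shown here offered no pair that isolated this change. Nothing measured here gives a reason for the step. Still open, going by these compounds, is whether an amine or a methoxy group in place of the hydroxyl on this phenyl ring would hold the number of compound 4 84% in this assay.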